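The source may hold more compounds than are shown below. What is called first, only, known or untested is meant among the compounds shown, and "the series" means these compounds.

Working notes on the series around compound 1 `COc1cccc(NC(=O)c2ccc3cccc(O)c3n2)c1`. In an ADME assay on THP-1 cells (Homo sapiens) for cytotoxicity, read by WST assay, with a stated time of 24 h (a higher number here means a weaker inhibitor, a lower number a stronger inhibitor), compound 1 gives > 30000 nM, which is a limit of the assay and not a number. Compound 2 `O=C(Nc1ccccc1Cl)c1ccc2cccc(O)c2n1` gives > 30000 nM in this assay, likewise a limit. Compound 3 `O=C(Nc1ccc(Cl)cc1)c1ccc2cccc(O)c2n1` gives > 30000 nM in this assay, again a limit. Among the measured compounds shown here, the one step between measured compounds that differ in a single place, a step that the two limits leave unreadable from compound 2 to compound 3, cannot be read: both of its ends are limits. All three measured values sit at the same limit (the limit of > 30000 nM in this assay, at which 3 of the 3 values shown sit), so compound 1 stands nowhere in particular among them and no ordering is readable.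

Compound 4 `O=C(Nc1cccc(Br)c1)c1ccc2cccc(O)c2n1` has not yet been measured in this assay. It differs from compound 1 by bromo in place of methoxy on an aromatic carbon. For the measured compounds named here, no measured step bears on this exchange; the only step available, an exchange of one chlorophenyl for another, lies unreadable between two limits. Going by the values given here, the sole guidance is that three of three values rest at the limit (the limit of > 30000 nM in this assay, at which 3 of the 3 values shown sit). A step from compound 1 to compound 4 in this assay beyond the scatter is therefore not expected in either direction, although the data cannot exclude one. The estimate for compound 4 in this assay is 40000 nM, with a range from 15000 nM to 120000 nM, and a further limit rather than a number is expected. The expected step is a step that the limit leaves unreadable from compound 1 to compound 4.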

Compound 4, half-maximal inhibitory concentration in the THP-1 assay: > 30000 nM
Compound 4 gave a limit, no number (the forecaster's own chance of this, stated with the estimate: 80%); the middle value is on the limit's open side.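

In the THP-1 assay compound 4 gives > 30000 nM, which is a limit of the assay and not a number. No new step can be read in the THP-1 assay: the steps joining compound 4 to compound 1, compound 2 and compound 3 all have limits at both ends. All four values stand at one limit: the limit of > 30000 nM in the THP-1 assay, at which 4 of the 4 values shown sit. The compounds shown leave open how these four rank in the THP-1 assay, and whether any exchange on the shared core gives a readable value. In a physicochemical assay for lipophilicity, read by HPLC (on this read-out lower numbers stand for lower lipophilicity and higher numbers for higher lipophilicity), compound 1 gives 2.5 and compound 4 gives 2.5.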